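The source may report more compounds than this note shows. Statements on the series, on what has been measured and on what is new or still open speak of the compounds shown alone.

Two amides on the shared core have numbers in a functional assay on A375P cells (Homo sapiens) for antiproliferative activity, read by MTT assay, with a stated time of 48 h; a higher number here means a weaker inhibitor, a lower number a stronger inhibitor. Compound 1 `COc1ccc(C(=O)Nc2cccc(-c3ccnc4c(NC(C)=O)cccc34)c2)cc1OC` gives 5300 nM. Compound 2 `CC(=O)Nc1cccc2c(-c3cccc(NC(=O)c4ccc(C)c(C)c4)c3)ccnc12` gives only a limit of the assay, > 20000 nM. Among the compounds with values here, the one measured step, an at least 3.7-fold higher number from compound 1 to compound 2 (0.57 log units; beyond the scatter), runs toward weaker inhibition and rests on (the limit of > 20000 nM in this assay, at which 1 of the 2 values shown sits), so its true size stays open. Compound 3 `CC(=O)Nc1cccc2c(-c3cccc(NC(=O)c4ccc(Br)c(C)c4)c3)ccnc12` is not yet measured; it differs from compound 2 by bromo in place of methyl on an aromatic carbon. Within the data shown here, no measured step touches the same position: the single measured step, an at least 3.7-fold higher number from compound 1 to compound 2 (0.57 log units; beyond the scatter), exchanges that ring as a whole and does not separate the two substituents from each other. Compound 2 stands where a number cannot be read, and from there the step from compound 2 to compound 3 has no anchor in either direction, so no step beyond the scatter is expected. Compound 3 is therefore expected to stay near the limit, estimated at 20000 nM in this assay, between 8000 nM and 40000 nM. The expected step of a number no higher from compound 2 to compound 3 (the limit leaves the size open) is no larger than the scatter.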

Compound 3, half-maximal inhibitory concentration: > 20000 nM
Compound 3 was reported as a limit; the forecaster's own chance of this, stated with the estimate: 60%; the middle value lies on the limit itself.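

In this assay compound 3 gives > 20000 nM, which is a limit of the assay and not a number. The change from 3,4-dimethoxyphenyl to 4-bromo-3-methylphenyl on the carbonyl carbon gives an at least 3.7-fold higher number from compound 1 to compound 3 (0.57 log units; beyond the scatter), so a second replacement of the 3,4-dimethoxyphenyl runs toward weaker inhibition, and with bromo instead of methyl on the aromatic carbon no readable number returns. The step from compound 2 to compound 3 cannot be read, because both compounds sit at the same limit: the limit of > 20000 nM in this assay, at which 2 of the 3 values shown sit.

On these data alone, whether bromo and methyl differ at all on this aromatic carbon stays open, as does the true size of the step away from compound 1. Also open, as far as these compounds go, is whether an amine or a carboxylic acid on this carbon, with the methyl group kept ortho to it, would give a readable number in this assay, as compound 1 does with 5300 nM.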